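From 2-cyanophenyl to 2-vinylphenyl

This account rests on a few compounds, and the source may have more. Where it says the series, first, only, none or still open, it means among the compounds named here.

In a functional assay (muscle tissue) with Cavia porcellus as the target (on this read-out lower numbers stand for an effect already at smaller amounts and higher numbers for an effect only at larger amounts of compound), compound 1 `COC(=O)C1=C(C)N=C(C)/C(=C(\O)OC)C1c1cc(Cl)cc(Cl)c1` stands at 93.3 nM and compound 2 `COC(=O)C1=C(C)N=C(C)/C(=C(\O)OC)C1c1ccccc1C#N` at 15.9 nM as the lowest of the two numbers. For the measured compounds named here, the only measured step is a 5.9-fold lower number from compound 1 to compound 2 (0.77 log units; beyond the scatter) with 2-cyanophenyl in place of 3,5-dichlorophenyl on a saturated ring carbon. It is modest and bears only loosely here. Going by the values given here, compound 3 `C=Cc1ccccc1C1C(C(=O)OC)=C(C)N=C(C)/C1=C(\O)OC` carries vinyl in place of cyano on an aromatic carbon and no measured step exchanges these two groups. In this assay the expected change is a 1.4-fold higher number from compound 2 to compound 3 (0.14 log units; within the scatter) with no step beyond the scatter anticipated. Compound 3 is estimated at 22 nM with an expected range from 6 nM to 80 nM as a working figure.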

Compound 3, half-maximal effective concentration: 4.47 nM
Compound 3: the middle estimate sits 4.9-fold (0.69 log units) above what was measured; the measured number lies below the stated range.
By their numbers in this assay, from the lowest: compound 3; then compound 2; then compound 1.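

In this assay the cyano group is not needed on this aromatic carbon: vinyl, with no hydrogen-bond acceptor, gives a 3.6-fold lower number from compound 2 to compound 3 (0.55 log units; beyond the scatter). Measured against the 3,5-dichlorophenyl of compound 1, the 2-vinylphenyl gives a 21-fold lower number from compound 1 to compound 3 (1.32 log units; beyond the scatter), the widest step among these compounds. Nothing available explains why vinyl gives the lower number.

Open, as far as these compounds go, is whether ethyl, ethynyl or a longer chain on the same carbon would move the number further, and how an amine there would read.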